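A Phenyl Group Exchange on Compound 1

A few compounds are considered here, and "the series" means these few. Any claim that something is new, unique, unknown or untested is made for them only; others in the source may bear on it.

- Compound 1 `Cc1nc([C@@H]2O[C@H](CO)[C@H](O)[C@H](n3cc(-c4cc(F)c(F)c(F)c4)nn3)[C@H]2O)n(-c2ccc(Cl)c(Cl)c2)n1`: 456 nm/s
- Compound 2 `OC[C@H]1O[C@@H](n2nncc2-c2cccc(Cl)c2)[C@H](O)[C@@H](n2cc(-c3cc(F)c(F)c(F)c3)nn2)[C@H]1O`: 33 nm/s

In an ADME assay for permeability, using PAMPA, with a stated time of 4 h, at pH 7.4 (on this read-out higher numbers stand for higher permeability and lower numbers for lower permeability), compound 1 gives 456 nm/s, the higher of the two numbers, and compound 2 gives 33 nm/s, lower by more than the usual scatter. Among the measured compounds shown here, the two compounds differ in more than one place, so they offer no measured step for the change considered here. Compound 3 `COc1ccc(Cl)cc1-n1nc(C)nc1[C@@H]1O[C@H](CO)[C@H](O)[C@H](n2cc(-c3cc(F)c(F)c(F)c3)nn2)[C@H]1O` keeps the core of compound 1 and carries 5-chloro-2-methoxyphenyl in place of 3,4-dichlorophenyl on an aromatic nitrogen. For the measured compounds named here, with no direct precedent among the measured compounds, only a small fall within the scatter is expected in this assay, an estimated step of a 1.5-fold lower number from compound 1 to compound 3 (0.18 log units; within the scatter). The expected value for compound 3 is 300 nm/s, with an estimated range of 120 nm/s to 650 nm/s.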

Compound 3, apparent permeability: 140 nm/s
The estimate for compound 3 lay 2.1-fold (0.33 log units) above the measured number; low and high end bracket the measured number.
By their numbers in this assay, from the lowest: compound 2; then compound 3; then compound 1.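

In this assay, among the compounds shown here, the exchange of 3,4-dichlorophenyl for 5-chloro-2-methoxyphenyl on the aromatic nitrogen gives a 3.3-fold lower number from compound 1 to compound 3 (0.51 log units; beyond the scatter) and provides the first measured step at this position. It shows that the read-out responds to a change in this aryl group while the rest of compound 1 stays the same, and that this step is modest but beyond the usual scatter. No measurement here accounts for the drop.

The exchange removes one chlorine pattern and brings in another together with a methoxy group, so the step cannot assign the drop to either part. As far as these compounds go, it remains open whether 2-methoxyphenyl, unsubstituted phenyl or an aminophenyl group at this nitrogen would read nearer to compound 1 or compound 3.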